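The source may report more compounds than this note shows. Statements on the series, on what has been measured and on what is new or still open speak of the compounds shown alone.

In a functional assay on A549 cells (Homo sapiens) for cytotoxicity, read by MTT assay, with a stated time of 72 h (a higher number here means a weaker inhibitor, a lower number a stronger inhibitor), compound 1 `CCOC(=O)c1c(C)oc2ncnc(Nc3cccc(C)c3)c12` gives > 1000000 nM, which is a limit and not a number. Compound 3 `CCOC(=O)c1c(C)oc2ncnc(Nc3cccc(Br)c3)c12` gives > 1000000 nM, also a limit, so the step that the two limits leave unreadable from compound 1 to compound 3 cannot be sized. Compound 2 `Cc1cccc(Nc2ncnc3oc(C)c(CO)c23)c1` gives 24000 nM. Compound 4 `Cc1oc2ncnc(Nc3cccc(Br)c3)c2c1CO` has hydroxymethyl in place of ethoxycarbonyl on an aromatic carbon of compound 3: hydroxymethyl in place of ethoxycarbonyl on an aromatic carbon. The same exchange has one measured precedent, the step of an at least 41-fold lower number from compound 1 to compound 2 (1.61 log units; beyond the scatter), which is large and beyond the scatter. A similarly large step to a lower number is therefore expected in this assay, though it rests on that single pair. The expected step is an at least 50-fold lower number from compound 3 to compound 4 (1.69 log units; beyond the scatter). For compound 4 the estimate is 20000 nM, with an expected range of 5000 nM to 80000 nM.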

Compound 4, half-maximal inhibitory concentration: 102000 nM
Compound 4: the middle estimate sits 5.1-fold (0.71 log units) below what was measured; measured number outside the range, above it.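

In this assay, with bromo in place of methyl, hydroxymethyl in place of ethoxycarbonyl again gives a lower number (an at least 9.8-fold lower number from compound 3 to compound 4 (0.99 log units; beyond the scatter)), so the direction seen on the core of compound 1 holds on a second core. Whether the size of the change differs between the two cores cannot be read: the same change on two cores in this assay, an at least 41-fold lower number (1.61 log units; beyond the scatter) from compound 1 to compound 2 and an at least 9.8-fold lower number (0.99 log units; beyond the scatter) from compound 3 to compound 4; the limit leaves it open whether they differ
The hydroxymethyl pair also gives a readable bromo in place of methyl step (a 4.3-fold higher number from compound 2 to compound 4 (0.63 log units; beyond the scatter)), whereas the corresponding ethoxycarbonyl pair cannot be read at its limits.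

Still open, as far as these compounds go, is how a carboxylic acid, an amine or a longer alcohol chain would read at this position. Also open, from the compounds shown here alone, is whether the lower number follows the hydroxyl itself or only the loss of ethoxycarbonyl.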